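A few compounds are considered here, and "the series" means these few. Any claim that something is new, unique, unknown or untested is made for them only; others in the source may bear on it.

Measured so far in a functional assay on HEK293 cells for antagonist activity at Voltage-dependent L-type calcium channel subunit alpha-1D (Rattus norvegicus), read by FLIPR; a lower number here means a stronger inhibitor, a higher number a weaker inhibitor:

Compound 1, `COC(=O)C1=C(C)NC(C)=C(C(=O)OCCCl)C1c1cccc([N+](=O)[O-])c1`: 22 nM
Compound 2, `COC(=O)C1=C(C)NC(C)=C(C(=O)OCc2ccccc2)C1c1cccc([N+](=O)[O-])c1`: 15 nM
Compound 3, `COC(=O)C1=C(C)NC(C)=C(C(=O)OCc2cc([N+](=O)[O-])cc([N+](=O)[O-])c2)C1c1cccc([N+](=O)[O-])c1`: 40 nM

All three share one core and differ only in the group carried on the ester oxygen. Compound 2 gives the lowest of the three numbers in this assay. Its gap to compound 1 is small: the step of a 1.5-fold lower number from compound 1 to compound 2 (0.17 log units; within the scatter) stays within the scatter. Its gap to compound 3 is larger: the step of a 2.7-fold higher number from compound 2 to compound 3 (0.43 log units; beyond the scatter) is the only one here that goes beyond the scatter, and even that is modest.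

Compound 4, `COC(=O)C1=C(C)NC(C)=C(C(=O)OC2Cc3ccccc3C2)C1c1cccc([N+](=O)[O-])c1`, is the next member of this ester series. It differs from compound 2 by 2,3-dihydro-1H-inden-2-yl in place of benzyl on an oxygen next to a carbonyl group. The two steps that touch the same position, a 1.5-fold lower number from compound 1 to compound 2 (0.17 log units; within the scatter) and a 2.7-fold higher number from compound 2 to compound 3 (0.43 log units; beyond the scatter), both show that swapping this group moves the number only a little. A step of similar size is expected for compound 4: a 1.3-fold higher number from compound 2 to compound 4 (0.12 log units; within the scatter), that is, no change beyond the scatter. The estimate for compound 4 in this assay is 20 nM, with a range from 8 nM to 50 nM.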

Compound 4, half-maximal inhibitory concentration: 43 nM
For compound 4 the middle estimate is 2.2-fold (0.33 log units) below the measured one; the range from low to high includes it.
By their numbers in this assay, from the lowest: compounds 2, 1, 3 and 4 (each within the scatter of the next, the first and the last beyond it).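

Replacing benzyl with 2,3-dihydro-1H-inden-2-yl on this oxygen gives a 2.9-fold higher number from compound 2 to compound 4 (0.46 log units; beyond the scatter) and shows that a carbon-only group with no hydrogen-bond acceptors can also move the number beyond the scatter, a modest step like the one to the 3,5-dinitrophenyl group of compound 3. The comparison with the smaller 2-chloroethyl group gives a 2.0-fold higher number from compound 1 to compound 4 (0.29 log units; within the scatter) and stays within the scatter, so only the benzyl compound stands clearly apart from compound 4. Nothing given here explains why the added five-membered non-aromatic ring has this effect.

The compounds shown leave open how the number responds to a chain ending in an amine or a carboxylic acid on this oxygen. They also leave open what a longer carbon chain between this oxygen and the phenyl ring would do.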